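Aryl ether to aryl thioether swap on the diamine core

The source may hold more compounds than are shown below. What is called first, only, known or untested is meant among the compounds shown, and "the series" means these compounds.

In a functional assay on EKVX cells (Homo sapiens) for inhibition, read by sulforhodamine B assay, with a stated time of 48 h (on this read-out lower numbers stand for stronger inhibition of growth and higher numbers for weaker inhibition of growth), compound 1 `Nc1cc(N)c2nc(-c3ccccc3)c(Oc3ccc(Cl)c(Cl)c3)nc2c1` gives 2140 nM, the second highest of the three numbers in hand. Compound 2 `COc1cc(CNc2nc3cc(N)cc(N)c3nc2-c2ccccc2)cc(OC)c1OC` gives 1950 nM, a number within the scatter of compound 1. Compound 3 `CCOC(=O)[C@H](CCC(=O)O)NC(=O)c1ccc(Oc2nc3cc(N)cc(N)c3nc2-c2ccccc2)cc1` gives 61700 nM, well beyond the scatter above compound 1. Going by the values given here, no step between two measured compounds that differ in one place is available, so the move to compound 4 `Nc1cc(N)c2nc(-c3ccccc3)c(Sc3ccc(F)cc3)nc2c1` rests on the structures alone: (4-fluorophenyl)sulfanyl in place of 3,4-dichlorophenoxy on an aromatic carbon. Without a comparable step to lean on, the expected step from compound 1 to compound 4 is a 1.4-fold higher number from compound 1 to compound 4 (0.15 log units; within the scatter), none beyond the scatter in either direction. Compound 4 is estimated at 3000 nM in this assay, with a range from 800 nM to 12000 nM.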

Compound 4, concentration for 50% growth inhibition: 20400 nM
Beside the measured number, compound 4's estimate is 6.8-fold (0.83 log units) below it; measured number outside the range, above it.
By their numbers in this assay, from the lowest: compounds 2 and 1 (each within the scatter of the next); then compound 4; then compound 3.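

In this assay, (4-fluorophenyl)sulfanyl in place of 3,4-dichlorophenoxy on this aromatic carbon gives a 9.5-fold higher number from compound 1 to compound 4 (0.98 log units; beyond the scatter), so the position of the shared core responds to this exchange. The exchange alters the linking atom and the halogens on the aryl ring together, and this single step cannot separate the two. Nothing measured here bears on the cause of the step. A 4-fluorophenoxy or a (3,4-dichlorophenyl)sulfanyl group would split the two changes. On these data alone, whether an amine link at this carbon, paired with either aryl group, behaves differently remains open.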